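A few compounds are considered here, and "the series" means these few. Any claim that something is new, unique, unknown or untested is made for them only; others in the source may bear on it.

Measured compounds:
- compound 1 `O=C(CCCCCCN(Cc1ccc2ccccc2c1)Cc1ccc2ccccc2c1)NO`: 5400 nM in an assay on cells for inhibition of histone deacetylase 8 (Homo sapiens), read by fluorescence, with a stated time of 24 h; a higher number here means a weaker inhibitor, a lower number a stronger inhibitor
- compound 2 `O=C(CCCCCCNCc1ccc([N+](=O)[O-])cc1)NO`: 2100 nM in this assay

Of the two compounds measured in this assay, compound 2 carries the lower number. Compound 1 stands above it, and the gap between the two lies beyond the usual scatter of repeated measurements, so compound 2 is the stronger inhibitor of this pair on the numbers shown. The two structures differ in more than one place, so nothing is claimed about the effect of any single change between them.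

Compound 3 `O=C(CCCCCCNCc1ccc(F)cc1)NO` has not yet been measured in this assay. It comes from compound 2 by one change: fluoro in place of nitro on an aromatic carbon. Going by the values given here, no step between measured compounds concerns this kind of change, so there is no direct guide to its size or direction. The shared core and the whole chain stay the same, and only the group at that aromatic carbon is exchanged. On that basis compound 3 is expected to give a number close to that of compound 2, with a step of a 1.4-fold higher number from compound 2 to compound 3 (0.15 log units; within the scatter) that may well fall within the scatter, leaning slightly toward a weaker inhibitor. Compound 3 is estimated at 3000 nM, with a likely range from 1000 nM to 9000 nM.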

Compound 3, half-maximal inhibitory concentration: 1700 nM
Compound 3: middle estimate off by 1.8-fold (0.25 log units), on the high side; the measured number falls inside the stated range.
By their numbers in this assay, from the lowest: compounds 3 and 2 (each within the scatter of the next); then compound 1.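

Going by these compounds alone, exchanging nitro for fluoro on this aromatic carbon, para to a large group, is the first change in a single place that can be read (a 1.2-fold lower number from compound 2 to compound 3 (0.09 log units; within the scatter)), and it leaves compound 2 and compound 3 within the scatter of each other in this assay. At this position, then, a group with hydrogen-bond acceptors and more heavy atoms can give way to a single fluorine with no shift that this measurement can resolve, although that rests on this one pair alone and says nothing of a trend across other groups. Nothing on hand explains this outcome.

The compounds shown leave open whether other groups at this carbon, such as an amine, a carboxylic acid or a methoxy group, would also stay within the scatter of compound 2 and compound 3, or whether one of them would move the number clearly. They also leave open what a longer chain or a shorter chain would do with fluoro held in place, since the chain is the same in all of the compounds compared here.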